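Notes on a substituted core: butyl against heteroatom-linked chains

The source may hold more compounds than are shown below. What is called first, only, known or untested is meant among the compounds shown, and "the series" means these compounds.

Measured so far:
compound 1 `CCCNc1nc(N)c2nc(O)n(Cc3ccccc3)c2n1`, in a functional assay (spleen, spleen) for activation, with Mus musculus as the target (on this read-out lower numbers stand for an effect already at smaller amounts and higher numbers for an effect only at larger amounts of compound), compound 1 gives 0.1 uM
compound 2 `CNc1nc(N)c2nc(O)n(Cc3ccccc3)c2n1`, compound 2 gives 1 uM
compound 3 `CCCCc1nc(N)c2nc(O)n(Cc3ccccc3)c2n1`, compound 3 gives 0.03 uM

Compound 3 stands at the lowest number of the three, with compound 1 nearest and compound 2 furthest. Two measured steps reach compound 3: a 3.3-fold lower number from compound 1 to compound 3 (0.52 log units; beyond the scatter) and a 33-fold lower number from compound 2 to compound 3 (1.52 log units; beyond the scatter). Both replace a chain that is attached through a nitrogen by butyl, and both lowered the number. The remaining step, a 10-fold higher number from compound 1 to compound 2 (1.00 log units; beyond the scatter), shortens the chain on the nitrogen and raises the number.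

Compound 4 `CCCSc1nc(N)c2nc(O)n(Cc3ccccc3)c2n1` differs from compound 3 by propylsulfanyl in place of butyl on an aromatic carbon. For the measured compounds named here, no measured step exchanges butyl for propylsulfanyl, so the two steps into compound 3 are the only guide: a chain attached through a heteroatom rather than carbon gave a higher number in each case, though that heteroatom was nitrogen, not sulfur. A rise of modest size is therefore expected, smaller than or similar to the step from compound 1 to compound 3, and a step of a 2.0-fold higher number from compound 3 to compound 4 (0.30 log units; within the scatter) is estimated. Compound 4 is expected to give about 0.06 uM, within a range of 0.02 uM to 0.2 uM.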

Compound 4, minimum effective concentration: 0.01 uM
Compound 4: middle estimate off by 6.0-fold (0.78 log units), on the high side; the measured number lies below the stated range.
By their numbers in this assay, from the lowest: compound 4; then compound 3; then compound 1; then compound 2.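

In this assay the heteroatom link on this aromatic carbon does not act in one direction: a 3.0-fold lower number from compound 3 to compound 4 (0.48 log units; beyond the scatter) puts a chain attached through sulfur under butyl, while the nitrogen-linked chains of compound 1 and compound 2 both stand over it, so the earlier trend holds for those two compounds and compound 4 goes against it. With propyl kept on the link, the exchange of propylamino for propylsulfanyl gives a 10-fold lower number from compound 1 to compound 4 (1.00 log units; beyond the scatter) and thus separates the linking atom from chain length, whereas the wider a 100-fold lower number from compound 2 to compound 4 (2.00 log units; beyond the scatter) changes both together. Nothing available accounts for the different behaviour of the sulfur and nitrogen links at this position.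

Going by these compounds, the response to chain length on sulfur remains open, as methylsulfanyl and hexylsulfanyl would show whether propylsulfanyl lies near an optimum or on a continuing trend. On these data alone, an oxygen link, as in propoxy, is also open, and it would show whether the lower number extends to another heteroatom at this aromatic carbon or stays with propylsulfanyl alone.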